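This account rests on a few compounds, and the source may have more. Where it says the series, first, only, none or still open, it means among the compounds named here.

Measured so far, in a functional assay on HCT-116 cells (Homo sapiens) for antiproliferative activity, read by MTT assay, with a stated time of 72 h; on this read-out lower numbers stand for stronger inhibition and higher numbers for weaker inhibition:

compound 1, `Nc1ccc2c(c1)OCCCN2S(=O)(=O)c1ccc(-c2cnc(C3CC3)o2)cc1`, gives 87 nM
compound 2, `COc1ccc2c(c1)N(S(=O)(=O)c1ccc(-c3cnc(C4CC4)o3)cc1)CCCO2`, gives 47 nM

Compound 1 stands at the higher of the two numbers in this assay. Its nearest neighbour on the numbers is compound 2, and the two values lie within the usual scatter of each other, so nothing can be read from their order.

Compound 3, `COc1ccc2c(c1)OCCCN2S(=O)(=O)c1ccc(-c2cnc(C3CC3)o2)cc1`, has not yet been measured in this assay. Compared with compound 1 it differs in one place: methoxy in place of amino on an aromatic carbon. Among the measured compounds shown here, no step between measured compounds covers this change, so its size is not known from the series itself. Given the narrow spread of the two numbers at hand, the step from compound 1 to compound 3 is expected to be small, at most a modest lowering of the number and possibly none beyond the scatter: a 1.5-fold lower number from compound 1 to compound 3 (0.16 log units; within the scatter).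

Compound 3 is estimated to give 60 nM in this assay, with an expected range from 25 nM to 150 nM.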

Compound 3, half-maximal inhibitory concentration: 223 nM
Compound 3: middle estimate off by 3.7-fold (0.57 log units), on the low side; the whole stated range lies below it.
By their numbers in this assay, from the lowest: compounds 2 and 1 (each within the scatter of the next); then compound 3.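

In this assay, methoxy in place of amino on an aromatic carbon gives a 2.6-fold higher number from compound 1 to compound 3 (0.41 log units; beyond the scatter). This shows that the position is sensitive to the group it carries: the step is modest but lies beyond the scatter, something the two earlier compounds, within the scatter of each other, could not show. The change removes the hydrogen-bond donor of the amino group, keeps one hydrogen-bond acceptor and adds one heavy atom, but nothing measured here ties the higher number to any of these differences.

With only amino and methoxy compared at this position, a single step cannot separate a gain from the amino group from a penalty from the methoxy group, and a hydroxyl group, a dimethylamino group or a plain hydrogen on the same aromatic carbon would help to tell the two apart. From the compounds shown here alone, whether the same step carries over to the core of compound 2 also remains open.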